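The compounds below may be only part of what the source reports. "The series", "measured", "known", "first", "only" and "open" are said of these compounds alone.

Of the compounds shown here, three sharing one core have been measured in a functional assay on MIA PaCa-2 cells (Homo sapiens) for inhibition, read by MTT assay, with a stated time of 72 h; on this read-out higher numbers stand for weaker inhibition of growth and lower numbers for stronger inhibition of growth. Compound 1 `O=[N+]([O-])c1ccc(S(=O)(=O)NCCCCCCNCc2ccc(Br)cc2)cc1` gives 9800 nM, compound 2 `O=S(=O)(NCCCCCCNCc1ccc(Br)cc1)c1cc(Cl)cc(Cl)c1` gives 12000 nM, and compound 3 `O=S(=O)(NCCCCCCNCc1ccc(Br)cc1)c1c(Cl)cccc1Cl` gives 14700 nM. Compound 3 sits alongside the other two: the change a 1.5-fold higher number from compound 1 to compound 3 (0.18 log units; within the scatter) and the change a 1.2-fold higher number from compound 2 to compound 3 (0.09 log units; within the scatter) both fall within the scatter, as does a 1.2-fold higher number from compound 1 to compound 2 (0.09 log units; within the scatter), so altering the aryl on the sulfonyl sulfur has so far left this read-out essentially unmoved. Compound 4 `O=S(=O)(NCCCCCCNCc1ccc(Br)cc1)c1c(Cl)cc(C(F)(F)F)cc1Cl` differs from compound 3 by trifluoromethyl in place of hydrogen on an aromatic carbon. Within the data shown here, no measured step adds a group of this kind, yet all three changes on that ring were within the scatter, so compound 4 is expected to show a change of about a 1.1-fold lower number from compound 3 to compound 4 (0.05 log units; within the scatter), with an estimated value of 13000 nM in the range 5000 nM to 35000 nM.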

Compound 4, concentration for 50% growth inhibition: 5670 nM
For compound 4 the middle estimate is 2.3-fold (0.36 log units) above the measured one, within the range that was stated.
By their numbers in this assay, from the lowest: compounds 4, 1, 2 and 3 (each within the scatter of the next, the first and the last beyond it).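

In this assay, among these compounds, trifluoromethyl in place of hydrogen on the aromatic carbon meta to two chloro groups gives a 2.6-fold lower number from compound 3 to compound 4 (0.41 log units; beyond the scatter), the only step here that passes the scatter. The earlier changes of the aryl on the sulfonyl sulfur left the number unmoved, so this ring does respond to at least one substitution, here towards stronger inhibition of growth. Nothing available accounts for this step.

On these data alone, whether a nitrile, a methoxy group or an amine at this position would do the same remains open. So does whether trifluoromethyl has this effect without the two chloro groups.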